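A few compounds are considered here, and "the series" means these few. Any claim that something is new, unique, unknown or untested is made for them only; others in the source may bear on it.

Values measured in a functional assay on A549 cells (Homo sapiens) for cytotoxicity, read by resazurin assay, with a stated time of 48 h (on this read-out lower numbers stand for stronger inhibition and higher numbers for weaker inhibition), are these:

- Compound 1 `C=C(C)[C@@H]1CC=C(CN(OC)[C@@H]2O[C@H](CO)[C@@H](O)[C@H](O)[C@H]2NC(=O)N(C)N=O)CC1` gives 185000 nM
- Compound 2 `C=C(C)[C@@H]1CC=C(CN(OC)C2O[C@H](CNC(=O)CCCCCCCCC)[C@@H](O)[C@H](O)[C@H]2O)CC1` gives 14000 nM
- Compound 3 `C=C(C)[C@@H]1CC=C(CN(OC)C2OC[C@@H](N=[N+]=[N-])[C@H](O)[C@H]2O)CC1` gives 76000 nM

Compound 2 has the lowest number of the three, which makes it the most potent of this small set. Even the nearest, compound 3, sits beyond the usual scatter from it, and compound 1 lies further off.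

Compound 4 `C=CCOC(=O)NC[C@H]1OC(N(CC2=CC[C@@H](C(=C)C)CC2)OC)[C@H](O)[C@@H](O)[C@@H]1O` has not yet been measured. It differs from compound 2 in one place, with allyloxy in place of nonyl on a carbonyl carbon. Among the measured compounds shown here, no two measured compounds differ in just one place, so the data offer no direct guide to this swap.

The only hint is a loose one. For the measured compounds named here, compound 2, the sole measured compound carrying nonyl, gives 14000 nM as its value, while compound 3, which lacks it and differs elsewhere too, gives 76000 nM as its value. A move to a higher number, meaning weaker inhibition, is therefore expected in this assay and probably one beyond the scatter. The expected size is a 3.6-fold higher number from compound 2 to compound 4 (0.55 log units; beyond the scatter) as an estimate. The estimate for compound 4 is 50000 nM with an expected range from 20000 nM to 130000 nM as its limits of confidence.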

Compound 4, half-maximal inhibitory concentration: 140000 nM
Compound 4: middle estimate off by 2.8-fold (0.45 log units), on the low side, and the stated range ends below it.
By their numbers in this assay, from the lowest: compound 2; then compounds 3, 4 and 1 (each within the scatter of the next, the first and the last beyond it).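

In this assay, the group on the carbonyl carbon whose other neighbour is the amide-type nitrogen proves to matter: putting allyloxy in place of nonyl gives a 10-fold higher number from compound 2 to compound 4 (1.00 log units; beyond the scatter) and thus a clear loss of inhibition. Among the compounds shown here, this is the first direct reading of a single change in this set, as the earlier compounds differed from one another in more than one place and could only hint at what nonyl contributes. No measurement here speaks to the cause of this loss, so the part played by the carbon atoms that leave, or by the oxygen and double bond that enter, stays unassigned.

Still open, going by these compounds, is how a plain butyl chain or a longer dodecyl chain on the same carbonyl carbon would read, since the swap from nonyl to allyloxy alters chain size and the atom joined to the carbonyl at once. On these data alone, it is also open how a chain ending in an amine or a carboxylic acid would behave there. A single pair of compounds sets no trend.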